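A few compounds are considered here, and "the series" means these few. Any claim that something is new, unique, unknown or untested is made for them only; others in the source may bear on it.

Of the compounds shown here, three have been tested in a functional assay on the whole organism (Tail, strain ICR) with Mus musculus as the target, in the tail flick test, with a stated time of 30 min, at a dose of 25 umol/kg by the oral route; a lower number here means a weaker effect, a higher number a stronger effect of the compound at the dose given. Compound 1, `O=C(CN(c1ncnc2c1ncn2C1CCCCO1)C1CC1)N[C@@H](CO)C(=O)OCc1ccccc1`, gives 27.8%. Compound 2, `N=C(N)NCCC[C@H](NC(=O)CN(c1nc(Cl)nc2[nH]cnc12)C1CC1)C(=O)OCc1ccccc1`, gives 23.2%. Compound 3, `C[C@@H](O)[C@H](NC(=O)CN(c1nc(Cl)nc2[nH]cnc12)C1CC1)C(=O)O`, gives 18.6%. The number for compound 2 sits in the middle of these three, yet it is within the usual scatter of both compound 1 and compound 3, so the three results cannot be told apart on this evidence.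

Compound 4, `CC[C@H](C)[C@H](NC(=O)CN(c1nc(Cl)nc2[nH]cnc12)C1CC1)C(=O)OCc1ccccc1`, shares the core of compound 2 and differs from it in one place: a group of 4 heavy atoms (4 carbon; no ring) in place of a group of 7 heavy atoms (4 carbon, 3 nitrogen; no ring), on a saturated chain carbon bound to an amide-type nitrogen and a carbonyl carbon

Among the measured compounds shown here, no pair of measured compounds differs in one place only, so there is no measured step to lean on here. The three numbers, all within the scatter of one another, give no sign that a change of the side group shifts the result much. The step of a number 0.8 percentage points higher from compound 2 to compound 4 (within the scatter) is therefore expected to be small and in no particular direction, staying within the scatter. For compound 4 the expected result is 24%, with a range from 12% to 38%.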

Compound 4, a percentage reported as activity, at one dose (the size of the read-out at that dose, not a potency): 41.4%
The estimate for compound 4 lay 17.4 percentage points below the measured number, outside the stated range (above it).
By their numbers in this assay, from the lowest: compounds 3, 2 and 1 (each within the scatter of the next); then compound 4.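

On the saturated chain carbon bound to an amide-type nitrogen and a carbonyl carbon, the side group matters in this assay: sec-butyl in place of the group of 7 heavy atoms gives a number 18.2 percentage points higher from compound 2 to compound 4 (beyond the scatter). This is the first change in one place among the compounds shown and the first difference beyond the scatter, so this position can move the read-out at the dose given. The entering group has 0 hydrogen-bond donors and 0 acceptors, against 3 donors and 1 acceptor in the group that leaves, but nothing measured explains the higher number, and this one step cannot separate these differences from the change in size.

Still open, going by these compounds, is whether a methyl group, a longer chain or a chain ending in an amine on this same carbon would give a number like that of compound 4. On these data alone, whether the step holds at another dose or time is also open.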